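The source may hold more compounds than are shown below. What is called first, only, known or untested is meant among the compounds shown, and "the series" means these compounds.

In a functional assay on L1210 cells (Mus musculus) for inhibition (on this read-out higher numbers stand for weaker inhibition and lower numbers for stronger inhibition), two compounds with a shared core have been measured: compound 1 (`C#CCN(Cc1ccc2nc(C)nc(O)c2c1)c1ccccc1`) and compound 2 (`C#CCN(Cc1ccc2nc(C)nc(O)c2c1)c1ccc(C#N)cc1`). Compound 1 gives > 6500 nM, which is a limit and not a number. From the compounds shown here alone, compound 2 gives > 5000 nM, which is also a limit, so its exact position is unknown. Compound 3 (`C#CCN(Cc1ccc2nc(C)nc(O)c2c1)c1ccc(C#N)c(C(F)(F)F)c1`) differs from compound 2 by one change: trifluoromethyl in place of hydrogen on an aromatic carbon, with the trifluoromethyl group ortho to a cyano group. Going by the values given here, the only measured step that bears on this is a step that the two limits leave unreadable from compound 1 to compound 2, a different substitution on the same ring, and it has no readable size. It therefore gives no direction or size to carry over, and no clear step is expected in this assay. For compound 3, the expected value is 5000 nM, within an estimated range of 1500 nM to 15000 nM. The expected step is a number no higher from compound 2 to compound 3 (the limit leaves the size open).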

Compound 3, half-maximal inhibitory concentration: > 2800 nM
Compound 3 gave a limit, no number; the forecaster's own chance of this, stated with the estimate: 60%; the middle value is on the limit's open side.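

Going by these compounds alone, compound 1, compound 2 and compound 3 all give limits and not numbers, and no step between them can be read. The compounds shown leave open how strongly any of the three inhibits, and whether cyano or trifluoromethyl changes that at all.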